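Cyclopentyl in place of oxan-4-yl on compound 1

The source may hold more compounds than are shown below. What is called first, only, known or untested is meant among the compounds shown, and "the series" means these compounds.

In a functional assay on MV4-11 cells (Homo sapiens) for antiproliferative activity, read by CellTiter-Glo, with a stated time of 72 h (a higher number here means a weaker inhibitor of growth, a lower number a stronger inhibitor of growth), compound 1 (`COCCN[C@H]1CC[C@H](Nc2cc(-c3csc(NCC4CCOCC4)n3)c(Cl)cn2)CC1`) gives 170 nM. Compound 3 (`COC[C@@H](C)N[C@H]1CC[C@H](Nc2cc(-c3csc(NCC4CCOCC4)n3)c(Cl)cn2)CC1`) gives 140 nM, level with compound 1 at a 1.2-fold lower number from compound 1 to compound 3 (0.08 log units; within the scatter). Compound 2 (`COCCCN[C@H]1CC[C@H](Nc2cc(-c3csc(NCC4CCOCC4)n3)c(Cl)cn2)CC1`) gives 1090 nM, the highest of the three numbers, and it stands apart through a 6.4-fold higher number from compound 1 to compound 2 (0.81 log units; beyond the scatter) and a 7.8-fold lower number from compound 2 to compound 3 (0.89 log units; beyond the scatter).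

Compound 4 (`COCCN[C@H]1CC[C@H](Nc2cc(-c3csc(NCC4CCCC4)n3)c(Cl)cn2)CC1`) keeps the group on the amine nitrogen of compound 1 and differs elsewhere: cyclopentyl in place of oxan-4-yl on a saturated chain carbon bound to a nitrogen on an aromatic ring. Among the measured compounds shown here, all three measured steps alter the group on the amine nitrogen, so none of them bears directly on this change, and no measured compound carries cyclopentyl. They show only that a small edit in this series can move the number by a modest amount, as large as a 6.4-fold higher number from compound 1 to compound 2 (0.81 log units; beyond the scatter). For the measured compounds named here, with no measured step at this place, no change beyond the scatter is expected, though the range is kept wide. The expected step is a 1.2-fold lower number from compound 1 to compound 4 (0.08 log units; within the scatter). For compound 4 the estimate is 140 nM, with an expected range from 50 nM to 420 nM.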

Compound 4, concentration for 50% growth inhibition: 2160 nM
Estimate against measurement, compound 4: 15-fold (1.19 log units) below, and the stated range ends below it.
By their numbers in this assay, from the lowest: compounds 3 and 1 (each within the scatter of the next); then compounds 2 and 4 (each within the scatter of the next).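

In this assay, the steps among compounds 1, 2 and 3 changed only the group on the amine nitrogen, whereas the change at this other place, cyclopentyl in place of oxan-4-yl on a saturated chain carbon bound to a nitrogen on an aromatic ring, gives a 13-fold higher number from compound 1 to compound 4 (1.10 log units; beyond the scatter). Among the compounds shown here, the number here is therefore sensitive to this group, and this single step is large, where the earlier steps were modest or within the scatter. The step replaces a six-membered ring holding one oxygen and one hydrogen-bond acceptor with a five-membered ring of carbon only, and nothing measured here accounts for the loss.

The compounds shown cannot separate ring size from the loss of the oxygen, which a cyclohexyl or an oxolan-3-yl group at this place would begin to do. They also leave open whether the step would be of similar size with the 1-(methoxymethyl)ethyl group of compound 3 on the amine nitrogen.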